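This account rests on a few compounds, and the source may have more. Where it says the series, first, only, none or still open, it means among the compounds named here.

In a functional assay on MDA-MB-231 cells (Homo sapiens) for inhibition, read by MTT assay, with a stated time of 48 h; a lower number here means a stronger inhibitor, a higher number a weaker inhibitor:
- compound 1 `Cn1c(/C=C2\SC(=O)N(CC(=O)Nc3cc(C(C)(C)C)on3)C2=O)nc2ccccc21`: 33800 nM
- compound 2 `Cn1c(/C=C2\SC(=O)N(CC(=O)N3CCCCC3)C2=O)nc2ccccc21`: > 50000 nM (a limit)
- compound 3 `CC1CN(C(=O)CN2C(=O)S/C(=C\c3nc4ccccc4n3C)C2=O)CC(C)O1`: > 50000 nM (a limit)

Going by the values given here, compound 1 holds the only true number in this set, 33800 nM. The other two results sit at the limit of > 50000 nM in this assay, at which 2 of the 3 values shown sit.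

Compound 4 `CC(C)n1c(/C=C2\SC(=O)N(CC(=O)Nc3cc(C(C)(C)C)on3)C2=O)nc2ccccc21` keeps the core and the carbonyl side chain of compound 1 and has isopropyl in place of methyl on an aromatic nitrogen.

The measured steps all change the group on the carbonyl carbon, and none changes this nitrogen. They are an at least 1.4-fold higher number from compound 1 to compound 2 (0.17 log units; that floor lies within the scatter) and an at least 1.4-fold higher number from compound 1 to compound 3 (0.17 log units; that floor lies within the scatter), while a step that the two limits leave unreadable from compound 2 to compound 3 gives no usable size. They therefore offer no direct guide to this change.

The expectation rests on compound 1 at 33800 nM, with no step beyond the scatter expected in this assay and no direction favoured. The estimated step is a 1.1-fold lower number from compound 1 to compound 4 (0.05 log units; within the scatter). For compound 4 the estimated value is 30000 nM. The expected range for compound 4 runs from 12000 nM to 50000 nM, and a result reported only as a limit remains possible.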

Compound 4, half-maximal inhibitory concentration: > 50000 nM
Compound 4 was reported as a limit; the forecaster's own chance of this, stated with the estimate: 25%; middle value at least 1.6-fold (0.22 log units) away from the limit.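

In this assay, this is the first change shown at the aromatic nitrogen, and isopropyl in place of methyl gives an at least 1.4-fold higher number from compound 1 to compound 4 (0.17 log units; that floor lies within the scatter). As far as these compounds go, compound 4 gives > 50000 nM, which is a limit and not a number, so the real size of the step stays unknown and a change beyond the scatter is not established. Compound 4 keeps the carbonyl side chain of compound 1 yet joins the compounds at the limit, so compound 1 remains the only one in the set with a true number: the limit of > 50000 nM in this assay, at which 3 of the 4 values shown sit.

Still open, from the compounds shown here alone, is how ethyl, benzyl or a chain ending in a carboxylic acid on this nitrogen would read in this assay. Also open, going by these compounds, is whether any such group, paired with the same side chain, would give a true number lower than that of compound 1.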